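Anilino methoxy removal in the Vero cytotoxicity series

The compounds below may be only part of what the source reports. "The series", "measured", "known", "first", "only" and "open" are said of these compounds alone.

Measured compounds in an ADME assay on Vero cells (Chlorocebus sabaeus) for cytotoxicity; on this read-out higher numbers stand for lower toxicity in this test and lower numbers for higher toxicity in this test:
compound 1 `CCN(CC)CN1C(=O)/C(=N/NC(=S)Nc2ccccc2)c2cc(Cl)ccc21` gives 100000 nM
compound 2 `CCN(CC)CN1C(=O)/C(=N/NC(=S)Nc2ccc(Cl)cc2)c2ccccc21` gives 20000 nM
compound 3 `CCN(CC)CN1C(=O)/C(=N/NC(=S)Nc2ccc(OC)cc2)c2ccccc21` gives 4000 nM

Compound 3 gives the lowest number of the three in this assay; compound 2 sits nearest, compound 1 furthest, both steps beyond the scatter. The step to compound 4 `CCN(CC)CN1C(=O)/C(=N/NC(=S)Nc2ccccc2)c2ccccc21` is hydrogen in place of methoxy on an aromatic carbon. For the measured compounds named here, only one measured step touches the same position on this ring: a 5.0-fold lower number from compound 2 to compound 3 (0.70 log units; beyond the scatter), a modest step, which shows that the group at this place moves the number well beyond the scatter. Going by the values given here, no measured pair shows hydrogen against methoxy directly; compound 1 carries an unsubstituted anilino ring but differs from compound 4 also by the chloro on the core, so its value can only be read as a hint that the unsubstituted ring tends to go with higher numbers. Taking away the methoxy is therefore expected to raise the number, by about a 5.0-fold higher number from compound 3 to compound 4 (0.70 log units; beyond the scatter). Compound 4 is estimated at 20000 nM in this assay, within 6000 nM to 70000 nM.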

Compound 4, minimum cytotoxic concentration: 100000 nM
Beside the measured number, compound 4's estimate is 5.0-fold (0.70 log units) below it; measured number outside the range, above it.
By their numbers in this assay, from the lowest: compound 3; then compound 2; then compounds 1 and 4 (each within the scatter of the next).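

In this assay taking away the methoxy gives a 25-fold higher number from compound 3 to compound 4 (1.40 log units; beyond the scatter) as a large step and taking away the chloro at the same place gives a 5.0-fold higher number from compound 2 to compound 4 (0.70 log units; beyond the scatter) as a modest one, so the unsubstituted anilino ring now has a direct reading. Across compound 2, compound 3 and compound 4, hydrogen at this place goes with the highest number, and methoxy with the lowest. Chloro on the core reads differently, since hydrogen in its place gives no change at the digits printed from compound 1 to compound 4 (within the scatter) and not the clear rise seen on the anilino ring.

On these data alone, whether an amine or a carboxylic acid at this place would also bring the number down remains open. Nothing available on these compounds offers an explanation for the size of these steps.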